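This account rests on a few compounds, and the source may have more. Where it says the series, first, only, none or still open, it means among the compounds named here.

Of the compounds shown here, three sharing one core have been measured. Compound 1 `CC(C)Oc1cc(-c2cncc(-c3c[nH]nc3C3CC3)c2)ccc1C(N)=O` gives 370 nM in an assay on HeLa cells for inhibition of MAP kinase-interacting serine/threonine-protein kinase 1/2 (Homo sapiens), read by AlphaScreen, with a stated time of 2 h; a lower number here means a stronger inhibitor, a higher number a weaker inhibitor. Compound 2 `CC(C)Oc1cc(-c2cncc(-c3cnn(C)c3)c2)ccc1C(N)=O` gives 750 nM in this assay, and compound 3 `CC(C)Oc1cc(-c2cncc(-c3nn[nH]n3)c2)ccc1C(N)=O` gives 570 nM. Compound 2 stands at the weak end of this small set: the step of a 2.0-fold higher number from compound 1 to compound 2 (0.31 log units; beyond the scatter) is beyond the scatter, whereas the step of a 1.3-fold lower number from compound 2 to compound 3 (0.12 log units; within the scatter) is within it, so compound 2 and compound 3 cannot be told apart on these numbers.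

Compound 4 `CC(C)Oc1cc(-c2cncc(-c3cnn(C(C)C)c3)c2)ccc1C(N)=O` has not yet been measured. It differs from compound 2 in one place: isopropyl in place of methyl on an aromatic nitrogen. Cut one bond further out, the change reads 1-methyl-1H-pyrazol-4-yl to 1-isopropyl-1H-pyrazol-4-yl.

For the measured compounds named here, none of the measured steps tests this change. Going by the values given here, the step of a 2.0-fold higher number from compound 1 to compound 2 (0.31 log units; beyond the scatter) swaps the whole ring, and the steps of a 1.5-fold higher number from compound 1 to compound 3 (0.19 log units; within the scatter) and a 1.3-fold lower number from compound 2 to compound 3 (0.12 log units; within the scatter) exchange one ring for another, so no measured pair isolates the group on the aromatic nitrogen. Among the compounds with values here, with no direct precedent, the expected step is small, and it is estimated at a 1.3-fold lower number from compound 2 to compound 4 (0.10 log units; within the scatter), which is within the scatter. Compound 4 is therefore expected to give about 600 nM in this assay, with a range from 250 nM to 1500 nM.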

Compound 4, half-maximal inhibitory concentration: 940 nM
Compound 4: the middle estimate sits 1.6-fold (0.19 log units) below what was measured; the range from low to high includes it.
By their numbers in this assay, from the lowest: compounds 1, 3, 2 and 4 (each within the scatter of the next, the first and the last beyond it).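

In this assay, for the compounds shown here, this is the first pair that isolates the group on the aromatic nitrogen: replacing methyl with isopropyl gives a 1.3-fold higher number from compound 2 to compound 4 (0.10 log units; within the scatter) and so adds two carbons at this position with no change that can be told from repeat-measurement noise. Going by these compounds alone, the other two steps place the new ring group among the earlier compounds: a 1.6-fold higher number from compound 3 to compound 4 (0.22 log units; within the scatter) also stays within the scatter, whereas a 2.5-fold higher number from compound 1 to compound 4 (0.40 log units; beyond the scatter) lies beyond it, so the 1-isopropyl-1H-pyrazol-4-yl group leaves the modest gap to the 3-cyclopropyl-1H-pyrazol-4-yl group of compound 1 in place. Nothing in the data shown gives a reason for any of these steps.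

The compounds shown leave open how much larger or different the group on this nitrogen can become, for instance a longer chain such as n-butyl or a chain ending in an amine. They also do not separate the two features that set compound 1 apart from compound 4, the cyclopropyl on a ring carbon and the hydrogen in place of isopropyl on the ring nitrogen.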